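The source may report more compounds than this note shows. Statements on the series, on what has been measured and on what is new or still open speak of the compounds shown alone.

Measured compounds in a functional assay on cells for agonist activity at Glucose-dependent insulinotropic receptor (Homo sapiens), read by a luciferase reporter, with a stated time of 4 h; a higher number here means a larger maximal response, a lower number a smaller maximal response:

compound 1, `CC(O)c1cnc(N2CCC(c3coc4c(N5CCc6cc(S(C)(=O)=O)ccc65)ncnc34)CC2)nc1`, gives 33%
compound 2, `CC(C)(C)OC(=O)N1CCC(c2csc3c(Nc4ccc(S(C)(=O)=O)cc4F)ncnc23)CC1`, gives 82%
compound 3, `CC(C)(C)OC(=O)N1CCC(c2c[nH]c3c(Nc4ccc(S(C)(=O)=O)cc4F)ncnc23)CC1`, gives 9%

Compound 1 stands second of the three numbers in this assay. Its nearest neighbour is compound 3, whose maximal response lies lower by a margin beyond the scatter; compound 2 lies higher by a wider margin, also beyond the scatter. Neither compound 2 nor compound 3 differs from compound 1 in a single place, so no one-step comparison between measured compounds is available, and the two values of compounds 2 and 3 say only that the maximal response in this series can move over a broad range.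

Compound 4, `CS(=O)(=O)c1ccc2c(c1)CCN2c1ncnc2c(C3CCN(c4ncc(O)cn4)CC3)coc12`, is the next compound to go into this assay. It differs from compound 1 in one place: hydroxy in place of 1-hydroxyethyl on an aromatic carbon. The shared core, the piperidine linkage and the sulfonyl-bearing part are unchanged; the count of donors and acceptors is unchanged, and only two carbon atoms leave.

Among the compounds with values here, with no measured step of this kind to lean on, a small step is expected, most likely none beyond the scatter, with a slight downward tendency if any: the expected step is a number 3 percentage points lower from compound 1 to compound 4 (within the scatter). Compound 4 is therefore estimated to give 30% in this assay, within a range of 15% to 50%.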

Compound 4, largest response reached (Emax), in percent of the reference or control that the assay uses: 145%
Estimate against measurement, compound 4: 115 percentage points below, and the stated range ends below it.
By their numbers in this assay, from the lowest: compound 3; then compound 1; then compound 2; then compound 4.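

In this assay, hydroxy in place of 1-hydroxyethyl on an aromatic carbon of the six-membered aromatic ring with 2 nitrogen, para to a large group, gives a number 112 percentage points higher from compound 1 to compound 4 (beyond the scatter). Within the data shown here, this is the first one-place comparison, and it shows that this position alone can shift the maximal response by a large margin, even though the leaving and entering groups carry the same count of hydrogen-bond donors and acceptors and the shared core, the piperidine linkage and the sulfonyl-bearing part stay the same. No measurement shown bears on the reason for this step.

With a single pair at this position, the step cannot yet be assigned to the loss of the 2 carbon atoms or to the hydroxy standing directly on the ring, and a hydroxymethyl, methoxy, amine or carboxylic acid at the same place would help separate these two readings. Also open, as far as these compounds go, is whether the same exchange carries over to other cores, since compound 2 and compound 3 differ from this pair in more than one place and offer no comparison.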